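A few compounds are considered here, and "the series" means these few. Any claim that something is new, unique, unknown or untested is made for them only; others in the source may bear on it.

For the measured compounds named here, in a functional assay on MDA-MB-231 cells (Homo sapiens) for antiproliferative activity, read by MTT assay, with a stated time of 72 h (on this read-out lower numbers stand for stronger inhibition and higher numbers for weaker inhibition), compound 1 `O=C(CCc1cccc2c1B(O)OC2)Nc1cccc(I)c1` gives 5300 nM and compound 2 `O=C(CCc1cccc2c1B(O)OC2)Nc1cccc(-c2cccc(C(F)(F)F)c2)c1` gives 410 nM as the lower of the only two numbers so far. Going by the values given here, the single measured step is a 13-fold lower number from compound 1 to compound 2 (1.11 log units; beyond the scatter) and it is large. That step replaces iodo with a whole 3-(trifluoromethyl)phenyl group, so it bears on the next change only indirectly.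

Compound 3 `O=C(CCc1cccc2c1B(O)OC2)Nc1cccc(-c2ccc(C(F)(F)F)cc2)c1` differs from compound 2 in one place, with 4-(trifluoromethyl)phenyl in place of 3-(trifluoromethyl)phenyl on an aromatic carbon of a six-membered aromatic ring of carbon only, meta to a large group (4-(trifluoromethyl)phenyl in place of 3-(trifluoromethyl)phenyl on an aromatic carbon). Among the compounds with values here, no measured pair shows what this exchange does in this assay and no direction is firmly indicated. The expectation therefore starts from compound 2 at 410 nM and allows for no step beyond the scatter. The estimated step is a 1.2-fold higher number from compound 2 to compound 3 (0.09 log units; within the scatter) and it is expected to stay within the scatter. Compound 3 is expected at 500 nM with an estimated range from 180 nM to 1400 nM on this read-out.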

Compound 3, half-maximal inhibitory concentration: 510 nM
For compound 3 the middle estimate is 1.0-fold (0.01 log units) below the measured one, within the range that was stated.
By their numbers in this assay, from the lowest: compounds 2 and 3 (each within the scatter of the next); then compound 1.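

In this assay, 4-(trifluoromethyl)phenyl in place of 3-(trifluoromethyl)phenyl, on an aromatic carbon meta to a large group, gives a 1.2-fold higher number from compound 2 to compound 3 (0.09 log units; within the scatter), so this read-out does not separate these two groups, which hold the same atoms joined differently. With a 10-fold lower number from compound 1 to compound 3 (1.02 log units; beyond the scatter) alongside a 13-fold lower number from compound 1 to compound 2 (1.11 log units; beyond the scatter), a large step away from iodo at this place now holds for two trifluoromethyl-bearing phenyl groups rather than one, and no compound shown goes against this. Nothing at hand accounts for either observation.

A plain phenyl, or a phenyl carrying a nitrile, a methoxy group or an amine, at this same place would help show whether the step away from iodo follows the added phenyl ring or needs the trifluoromethyl group as well. Going by these compounds, the shared core and the chain joining it to the amide carbonyl are identical in all three compounds, so what a longer chain or a carboxylic acid there would do in this assay remains open.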